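The compounds below may be only part of what the source reports. "The series", "measured", "known", "first", "only" and "open" are said of these compounds alone.

Working notes on the cyanoguanidine chromanol series, measured in a functional assay (aorta) with Rattus norvegicus as the target; on this read-out higher numbers stand for weaker inhibition and lower numbers for stronger inhibition.

Of the compounds shown here, three have numbers so far. Compound 1 `CC1(C)Oc2ccc(C#N)cc2[C@@H](/N=C(\NC#N)Nc2ccc(N)cc2)[C@@H]1O` gives 3500 nM in this assay. Compound 2 `CCC(C)(C)/N=C(\NC#N)N[C@@H]1c2cc(C#N)ccc2OC(C)(C)[C@H]1O`, which carries a tert-pentyl group in place of the aryl amine, gives 29800 nM. Compound 3 `CC1(C)Oc2ccc(C#N)cc2[C@@H](n2c(O)nc3ccccc32)[C@@H]1O`, in which the cyanoguanidine is replaced by a benzimidazolone attached through nitrogen, gives 41000 nM. Compound 1 therefore stands lowest of the three, and its gaps to compound 2 and to compound 3 both lie beyond the usual scatter, so on these numbers it is the strongest inhibitor of the set.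

The next compound, compound 4 `CC1(C)Oc2ccc(C#N)cc2[C@@H](/N=C(\NC#N)Nc2cccc(C(=O)O)c2)[C@@H]1O`, keeps the whole core of compound 1 and changes only the aryl group on the guanidine: 3-carboxyphenyl in place of 4-aminophenyl on an amine nitrogen. For the measured compounds named here, no measured pair shows this particular change, so its size cannot be read from the data. Only compound 1 bears an aryl group on this nitrogen, and the other two compounds change different parts of the molecule.

The expectation for the step from compound 1 to compound 4 is a moderate weakening, a 3.4-fold higher number from compound 1 to compound 4 (0.54 log units; beyond the scatter), beyond the scatter but less than the gap to compound 2. Compound 4 is thus estimated at 12000 nM, with a range from 3000 nM to 50000 nM.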

Compound 4, half-maximal inhibitory concentration: > 100000 nM
Compound 4: only a limit was reported; the forecaster's own chance of this, stated with the estimate: 10%; at least 8.3-fold (0.92 log units) between middle value and limit.
By their numbers in this assay, from the lowest: compound 1; then compounds 2 and 3 (each within the scatter of the next). At a limit, above all of these: compound 4.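

For the compounds shown here, this is the first pair that differs in one place only, and it shows that the aryl group on this amine nitrogen can carry the read-out on its own: with the shared core unchanged, 3-carboxyphenyl in place of 4-aminophenyl gives an at least 28-fold higher number from compound 1 to compound 4 (1.45 log units; beyond the scatter). The step is large, yet its true size is not fixed, since in this assay compound 4 gives > 100000 nM, which is a limit of the assay and not a number. That limit is the only one in the series so far, and it marks the top of what can be read for compound 4: the limit of > 100000 nM in this assay, at which 1 of the 4 values shown sits.

The change replaces the amino group with a carboxyl group and also alters the number in the group name, so this single pair cannot separate the identity of the substituent from where it stands on the aromatic ring. On these data alone, what a plain phenyl group, a methyl ester or a primary amide would give on this nitrogen remains open, as does how far the step extends beyond the limit.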